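The source may hold more compounds than are shown below. What is called first, only, known or untested is meant among the compounds shown, and "the series" means these compounds.

Measured so far in a functional assay on A-375 cells (Homo sapiens) for antiproliferative activity, read by CCK-8 assay, with a stated time of 72 h, tested at 2 uM; a lower number here means a weaker effect, a higher number a stronger effect of the compound at the concentration tested:
- compound 1 `Nc1ccccc1NC(=O)c1ccc(CSC(=S)N2CCN(Cc3ccccn3)CC2)cc1`: 20.7%
- compound 2 `Nc1ccccc1NC(=O)c1ccc(CSC(=S)N2CCN(c3ccc(Cl)cc3)CC2)cc1`: 32.2%
- compound 3 `N#Cc1ccc(N2CCN(C(=S)SCc3ccc(C(=O)Nc4ccccc4N)cc3)CC2)cc1`: 41.4%

Compound 3 holds the highest of the three numbers, but the gap to compound 2, a number 9.2 percentage points higher from compound 2 to compound 3 (within the scatter), lies within the scatter, so no order between these two can be claimed. The gap to compound 1, a number 20.7 percentage points higher from compound 1 to compound 3 (beyond the scatter), is beyond the scatter.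

The next compound is compound 4 `Nc1ccccc1NC(=O)c1ccc(CSC(=S)N2CCN(c3ncccn3)CC2)cc1`. Its difference from compound 3 is pyrimidin-2-yl in place of 4-cyanophenyl on an amine nitrogen in a ring.

Going by the values given here, two measured steps bear on this change. Replacing (pyridin-2-yl)methyl on the ring nitrogen with an aromatic ring bound directly to that nitrogen gave a number 11.5 percentage points higher from compound 1 to compound 2 (beyond the scatter) and a number 20.7 percentage points higher from compound 1 to compound 3 (beyond the scatter), both modest. The exchange of cyano for chloro on that ring, a number 9.2 percentage points higher from compound 2 to compound 3 (within the scatter), stayed within the scatter. Compound 4 keeps a six-membered aromatic ring directly on the ring nitrogen, so the larger part of the gain seen in those steps is plausibly retained. Among the compounds with values here, no measured step shows what the two ring nitrogens of pyrimidin-2-yl do in place of the carbon-only ring with its nitrile, so only a small step, if any, beyond the scatter is expected, more likely downward than upward.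

In this assay compound 4 is expected to give about 33%, with a range from 18% to 48%. This estimate corresponds to an expected step of a number 8.4 percentage points lower from compound 3 to compound 4 (within the scatter).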

Compound 4, a percentage reported as inhibition, at one concentration (the size of the read-out at that concentration, not a potency): 24%
Estimate against measurement, compound 4: 9 percentage points above; the range from low to high includes it.
By their numbers in this assay, from the lowest: compounds 1, 4, 2 and 3 (each within the scatter of the next, the first and the last beyond it).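

In this assay, being a six-membered aromatic ring on the amine nitrogen in the ring is not enough to fix the read-out: pyrimidin-2-yl in place of 4-cyanophenyl gives a number 17.4 percentage points lower from compound 3 to compound 4 (beyond the scatter), so the make-up of the ring counts at this position, which the earlier exchange of cyano for chloro could not show. Pyrimidin-2-yl does not separate from either of the other groups, with a number 8.2 percentage points lower from compound 2 to compound 4 (within the scatter) and a number 3.3 percentage points higher from compound 1 to compound 4 (within the scatter), so the gain over (pyridin-2-yl)methyl seen with 4-cyanophenyl does not carry over to this ring with 2 hetero atoms. No evidence at hand accounts for the loss, and this single change both replaces ring carbons with nitrogens and removes the nitrile.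

Which of these two differences goes with the lower number stays open; an unsubstituted phenyl or a pyridin-2-yl ring on the same nitrogen would help to separate them. Also open, as far as these compounds go, is how a 5-cyanopyrimidin-2-yl group, which carries both the ring nitrogens and the nitrile, or a carboxylic acid on the phenyl ring would read in this assay.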